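Working notes: from compound 2 to compound 3

The source may hold more compounds than are shown below. What is called first, only, known or untested is meant among the compounds shown, and "the series" means these compounds.

- compound 1 `CCNc1cc(-c2ccc(NC(=O)Nc3ccc(C)cc3)cc2C)ccn1` gives 22000 nM
- compound 2 `CCNc1cc(-c2ccc(NC(=O)Nc3ccc(C)cc3)cc2C(F)(F)F)ccn1` gives 27100 nM

In a functional assay on BT-483 cells (Homo sapiens) for cytotoxicity, read by MTT assay, with a stated time of 24 h (a lower number here means a stronger inhibitor, a higher number a weaker inhibitor), compound 2 gives 27100 nM, which lies within the scatter of compound 1 at 22000 nM, so the two cannot be ranked. Compound 3 `CCNc1cc(-c2ccc(NC(=O)Nc3c(C)cccc3C)cc2C(F)(F)F)ccn1` has not yet been measured. Its difference from compound 2 is 2,6-dimethylphenyl in place of 4-methylphenyl on an amide-type nitrogen. Going by the values given here, the only measured step is a 1.2-fold higher number from compound 1 to compound 2 (0.09 log units; within the scatter), for trifluoromethyl in place of methyl on an aromatic carbon. Among the compounds with values here, it lies within the scatter and sits at a different place, so no measured step speaks directly to this change. No direction can be drawn from the data, and the expected change in this assay is none beyond the scatter. The estimated step is a 1.1-fold lower number from compound 2 to compound 3 (0.04 log units; within the scatter). Compound 3 is estimated at 25000 nM, with an expected range from 11000 nM to 55000 nM.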

Compound 3, half-maximal inhibitory concentration: 22000 nM
Compound 3: the middle estimate sits 1.1-fold (0.06 log units) above what was measured; the range from low to high includes it.
By their numbers in this assay, from the lowest: compounds 1, 3 and 2 (each within the scatter of the next).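

In this assay, 2,6-dimethylphenyl in place of 4-methylphenyl on the amide-type nitrogen gives a 1.2-fold lower number from compound 2 to compound 3 (0.09 log units; within the scatter). Going by these compounds alone, this is the first measured change at this place, and it shows that this exchange of aromatic groups leaves the number within the scatter; the earlier step, trifluoromethyl in place of methyl, stood at a different place and was also within the scatter. No measurement at hand bears on why this change leaves the number where it is.

Still open, on these data alone, is whether any group on this nitrogen moves the number beyond the scatter, for instance a phenyl ring carrying a carboxylic acid or an amine, or a saturated cyclohexyl ring. Also open, as far as these compounds go, is whether a longer chain in place of the ethyl group on the amine of the shared core would do so.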